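Pentyl to cyclohexylmethyl on the shared core

The source may hold more compounds than are shown below. What is called first, only, known or untested is meant among the compounds shown, and "the series" means these compounds.

Measured compounds:
compound 1 `CCCCCc1nn(C[C@H]2CCCN2C)c(=O)c2ccccc12` — 501 nM
compound 2 `CN1CCCCC(n2nc(Cc3ccc(Cl)cc3)c3ccccc3c2=O)C1` — 158 nM
compound 3 `CN(CCCCc1ccc(OCCCN2CCCCCC2)cc1)CCn1nc(Cc2ccc(Cl)cc2)c2ccccc2c1=O` — 1580 nM

In an assay for binding affinity to Alpha-1A adrenergic receptor (Homo sapiens) (a lower number here means a stronger inhibitor, a higher number a weaker inhibitor), compound 1 stands second highest of the three numbers. Among the measured compounds shown here, compound 2 shows a lower number and compound 3 a higher one, each beyond the scatter; no single-point step links them to compound 1, so only their values are compared. Compound 4 `CN1CCC[C@@H]1Cn1nc(CC2CCCCC2)c2ccccc2c1=O` is not yet measured in this assay. Relative to compound 1 it carries cyclohexyl in place of butyl on a saturated chain carbon bound to an aromatic carbon. For the measured compounds named here, with no step of this kind measured, a modest move toward a lower number is expected, quite possibly within the scatter. Compound 4 is estimated at 250 nM, range 80 nM to 800 nM, so the expected step is a 2.0-fold lower number from compound 1 to compound 4 (0.30 log units; within the scatter).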

Compound 4, inhibition constant: > 1990 nM
Compound 4 was reported as a limit; the forecaster's own chance of this, stated with the estimate: 2%; middle value at least 7.9-fold (0.90 log units) away from the limit.
By their numbers in this assay, from the lowest: compound 2; then compound 1; then compound 3. At a limit, above all of these: compound 4.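

Compound 4 is reported only as a limit in this assay, > 1990 nM. Cyclohexyl in place of butyl on a saturated chain carbon bound to an aromatic carbon gives an at least 3.9-fold higher number from compound 1 to compound 4 (0.59 log units; beyond the scatter), the first single-change step in the series, showing that affinity at this position is sensitive to this change. The real size of the step remains unknown, since only its minimum can be read: the limit of > 1990 nM in this assay, at which 1 of the 4 values shown sits.

The change brings in both a ring and added carbons. These two cannot be separated here. A straight hexyl chain at this position would distinguish them.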